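This account rests on a few compounds, and the source may have more. Where it says the series, first, only, none or still open, it means among the compounds named here.

Three compounds built on a shared core were tested in a functional assay on K562 cells (Homo sapiens) for inhibition, read by sulforhodamine B assay, with a stated time of 48 h; on this read-out lower numbers stand for stronger inhibition of growth and higher numbers for weaker inhibition of growth. Compound 1 `Nc1cc(N)c2nc(-c3ccccc3)c(Oc3ccc(Cl)c(Cl)c3)nc2c1` gives 3550 nM in this assay. Compound 3 `COc1cc(CNc2nc3cc(N)cc(N)c3nc2-c2ccccc2)cc(OC)c1OC` gives 1780 nM, and the gap between these two numbers lies within the usual scatter of repeated measurements, so neither can be called the stronger of the pair. Compound 1 thus holds the higher of the two numbers, with compound 3 nearest to it. For compound 2 `CCOC(=O)[C@H](CCC(=O)O)NC(=O)c1ccc(Sc2nc3cc(N)cc(N)c3nc2-c2ccccc2)cc1` this assay reported only a limit, > 10 nM, and not a number (the limit of > 10 nM in this assay, at which 1 of the 3 values shown sits). No pair among these three compounds differs in a single place, so no measured step is available to guide what follows.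

Compound 4 `COc1ccc(Sc2nc3cc(N)cc(N)c3nc2-c2ccccc2)cc1` has not yet been measured. It differs from compound 1 in that ((4-methoxyphenyl)sulfanyl in place of 3,4-dichlorophenoxy on an aromatic carbon). Without a measured step of this kind, the change is expected a 1.4-fold lower number from compound 1 to compound 4 (0.15 log units; within the scatter), that is, nothing beyond the scatter in either direction. Compound 4 is therefore estimated at 2500 nM, within a range from 600 nM to 10000 nM.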

Compound 4, concentration for 50% growth inhibition: 9770 nM
For compound 4 the middle estimate is 3.9-fold (0.59 log units) below the measured one, and the stated range covers the measured number.
By their numbers in this assay, from the lowest: compounds 3 and 1 (each within the scatter of the next); then compound 4.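

In this assay, putting (4-methoxyphenyl)sulfanyl in place of 3,4-dichlorophenoxy gives a 2.8-fold higher number from compound 1 to compound 4 (0.44 log units; beyond the scatter), a modest weakening of growth inhibition and the first measured sign that this aromatic carbon, next to the ring nitrogen, responds to what it carries. The two groups have the same heavy-atom count and each holds one six-membered aromatic ring of carbon only, yet they are not interchangeable here. Nothing in the data shown explains this shift.

The swap alters the linking atom and the ring's substituents together, so the compounds shown leave open which of the two changes matters, since none pairs a sulfur link with the 3,4-dichlorophenyl ring. Also open, going by these compounds, is how a piperazine or a simple hydroxyl group would fare on this same carbon.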